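A few compounds are considered here, and "the series" means these few. Any claim that something is new, unique, unknown or untested is made for them only; others in the source may bear on it.

The series shares one core, shown in compound 1 `COc1cc(/C=C/C(=O)Nc2cc3c(Nc4ccc(F)c(Cl)c4)ncnc3cc2OC)cc(OC)c1`, compound 2 `COc1ccc(OC)c(/C=C/C(=O)Nc2cc3c(Nc4ccc(F)c(Cl)c4)ncnc3cc2OC)c1`, compound 3 `COc1cc2ncnc(Nc3ccc(F)c(Cl)c3)c2cc1NC(=O)/C=C/c1cc(OC)c(OC)c(OC)c1` and the unmeasured compound 4 `COc1ccc(/C=C/C(=O)Nc2cc3c(Nc4ccc(F)c(Cl)c4)ncnc3cc2OC)cc1`, and differs only in the aryl group on the double-bonded chain carbon. In a functional assay on MCF7 cells (Homo sapiens) for cytotoxicity, read by MTT assay, with a stated time of 72 h (on this read-out higher numbers stand for weaker inhibition and lower numbers for stronger inhibition), compound 1 gives 38500 nM. In this assay compound 2 gives 34300 nM. Within the data shown here, the only measured step, a 1.1-fold lower number from compound 1 to compound 2 (0.05 log units; within the scatter), is within the scatter, so the two dimethoxyphenyl variants cannot be ordered. Compound 3 stands apart: in this assay compound 3 is reported as "not active" (no number reported), and no number is given for it, so its position relative to compounds 1 and 2 cannot be placed on a scale.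

The step from compound 3 to compound 4 is 4-methoxyphenyl in place of 3,4,5-trimethoxyphenyl on a double-bonded chain carbon bound to a double-bonded chain carbon. Among the measured compounds shown here, no measured step bears directly on this change, and the one measured step concerns a different pair of aryl groups and is itself within the scatter. What the data offer is that all three measured compounds lie in the weak range or beyond it, with compound 3 giving no number at all. Compound 4 is therefore expected to fall in the same weak region, with a real chance that this assay again reports only a limit. On that basis compound 4 is estimated at 40000 nM, with a range from 15000 nM to 120000 nM.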

Compound 4, half-maximal inhibitory concentration: "not active" (no number reported)
Compound 4 has no reported number here, so the estimate cannot be set against anything.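

In this assay, among these compounds, compound 3 is "not active" (no number reported) and compound 4 is "not active" (no number reported) and so no step between them can be read. Nothing given here offers an explanation for this result. The compounds shown leave open how compound 3 and compound 4 would compare with compound 1 and compound 2 on a numerical scale.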